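This account rests on a few compounds, and the source may have more. Where it says the series, first, only, none or still open, it means among the compounds named here.

Measured compounds:

compound 1, `Cc1ccc(NC(=S)NC(=O)c2ccc(OCc3cccc(Cl)c3)cc2)cc1-c1nc2ccccc2[nH]1`: 43300 nM
compound 2, `O=C(NC(=S)Nc1ccc(Cl)c(-c2nc3ccccc3[nH]2)c1)c1ccc(OCc2ccc(Cl)c(Cl)c2)cc1`: 4600 nM
compound 3, `Cc1ccc(NC(=O)NC(=O)c2ccc(OCc3ccccc3)cc2)cc1-c1nc2ccccc2[nH]1`: 35100 nM

In a functional assay on MNK45 cells (Homo sapiens) for inhibition, read by MTT assay, with a stated time of 48 h (on this read-out lower numbers stand for stronger inhibition and higher numbers for weaker inhibition), compound 3 gives 35100 nM, the second highest of the three numbers. Its nearest neighbour is compound 1, whose number is a little higher but within the usual scatter, so no order between the two can be stated. The furthest is compound 2, whose number is lower by a gap beyond the scatter.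

Compound 4 is `Cc1ccc(NC(=O)NC(=O)c2ccc(OCc3ccc(F)cc3)cc2)cc1-c1nc2ccccc2[nH]1`. It differs from compound 3 in one place: fluoro in place of hydrogen on an aromatic carbon. For the measured compounds named here, no pair of measured compounds shows this change, so there is no measured step to lean on; the three numbers show only where compound 3 stands, not how this change moves a number.

With nothing measured for the change, the step from compound 3 to compound 4 in this assay is expected to be small, a 1.2-fold lower number from compound 3 to compound 4 (0.07 log units; within the scatter), not clearly beyond the scatter in either direction. Compound 4 is therefore estimated at 30000 nM, with a range from 12000 nM to 75000 nM.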

Compound 4, half-maximal inhibitory concentration: 240 nM
Estimate against measurement, compound 4: 130-fold (2.10 log units) above; the measured number lies below the stated range.
By their numbers in this assay, from the lowest: compound 4; then compound 2; then compounds 3 and 1 (each within the scatter of the next).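

In this assay, fluoro in place of hydrogen on an aromatic carbon, para to a large group, gives a large step, a 150-fold lower number from compound 3 to compound 4 (2.17 log units; beyond the scatter), well beyond the scatter. The earlier compounds shown here included no pair differing in one place, so they could not show that the number responds this strongly to a change at this position, where the benzyloxy group becomes (4-fluorobenzyl)oxy and only one heavy atom enters. Nothing available accounts for the size of this step.

This single pair leaves open whether a methoxy group, a nitrile or a trifluoromethyl group at the same place would move the number in the same way, or whether only fluoro does so. It also leaves open whether fluoro on another carbon of that ring, or on a compound with a different core, would give a comparable step.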